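Swapping the anilide ring for a pyridine in a quinoline ether amide

This account rests on a few compounds, and the source may have more. Where it says the series, first, only, none or still open, it means among the compounds named here.

Two compounds of this series carry a measured lipophilicity. Compound 1 `Cc1cc(C)cc(NC(=O)COc2cc(C)nc3ccc(OCc4ccccc4)cc23)c1` gives 7.03 in a physicochemical assay for lipophilicity, read by HPLC, in phosphate buffer, measured as chromatographic lipophilicity, at pH 7.4; a lower number here means a more polar compound, a higher number a more lipophilic compound. Compound 2 `COc1ccc2nc(C)cc(OCC(=O)Nc3cccc(C)c3)c2c1` gives 4.83 in this assay, the lower of the two numbers; compound 1 lies well above it, and that gap is beyond the scatter of the method. Going by the values given here, no single-change pair exists between compound 1 and compound 2, so only their two values can be compared.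

Compound 3 `COc1ccc2nc(C)cc(OCC(=O)Nc3c(C)cncc3C)c2c1` has not yet been measured. Compared with compound 2 it differs in one place: 3,5-dimethylpyridin-4-yl in place of 3-methylphenyl on an amide-type nitrogen. Nothing else about the shared core of compound 2 changes.

Among the compounds with values here, no measured step of this kind is available, so any expectation rests on compound 2 alone and on its value 4.83. The expected step from compound 2 to compound 3 in this assay is a number 1.13 log units lower from compound 2 to compound 3 (beyond the scatter), a move toward the polar side and beyond the scatter. Compound 3 is therefore expected to give about 3.7 in this assay, with a range from 3 to 4.4.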

Compound 3, distribution coefficient: 3.01
Compound 3: the middle estimate sits 0.69 log units above what was measured; low and high end bracket the measured number.
By their numbers in this assay, from the lowest: compound 3; then compound 2; then compound 1.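

In this assay, exchanging the group on the amide-type nitrogen gives a number 1.82 log units lower from compound 2 to compound 3 (beyond the scatter), a large step and the only single-change step among the compounds shown. Compound 1 and compound 2 differ in more than one place, so their values could not show what this position does on its own; this pair shows that exchanging the group on the amide-type nitrogen, with the shared core unchanged, is enough to move the reading well beyond the scatter. The entering group carries one ring hetero atom and 1 hydrogen-bond acceptor where the leaving group has 0, but nothing measured here tells which feature of the exchange accounts for the step.

Going by these compounds alone, the single step leaves open how much of it goes with the ring nitrogen and how much with the two methyl groups, a question that unsubstituted pyridin-4-yl on this amide-type nitrogen would address. It also leaves open whether the same exchange would move the reading by a similar amount on the core of compound 1.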